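Adding a methyl to the hydroxy oxygen of compound 3

The source may hold more compounds than are shown below. What is called first, only, known or untested is meant among the compounds shown, and "the series" means these compounds.

Values measured so far in a functional assay on the whole organism with Mus musculus as the target; a higher number here means that more compound is needed for the effect, a lower number that less compound is needed
Compound 1 `CC[C@@H](C(=O)NC)N1CCCC1=O` gives 1800 umol/kg
Compound 2 `CC[C@@H](C(=O)N(C)OC)N1CCCC1=O` gives 1000 umol/kg
Compound 3 `CC[C@@H](C(=O)NO)N1CCCC1=O` gives 1000 umol/kg

Compound 3 stands at 1000 umol/kg in this assay and reads level with compound 2 at the digits shown. The gap on the other side is a 1.8-fold lower number from compound 1 to compound 3 (0.26 log units; within the scatter) and so the three measured compounds cannot be ranked.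

Compound 4 `CC[C@@H](C(=O)NOC)N1CCCC1=O` has not yet been measured. It differs from compound 3 by methyl in place of hydrogen on an oxygen with methyl in place of hydrogen on an oxygen, so that hydroxyamino becomes methoxyamino.

Among the compounds with values here, no measured step makes exactly this change, but two come close. One is no change at the digits printed from compound 2 to compound 3 (within the scatter) where hydroxyamino takes the place of methoxy(methyl)amino on a carbonyl carbon. The other is a 1.8-fold lower number from compound 1 to compound 2 (0.26 log units; within the scatter) where methoxy takes the place of hydrogen on an amide-type nitrogen. Neither step leaves the scatter, and that includes the one that introduces a methoxy group. The change to compound 4 is therefore expected to be equally small, with no clear direction. The expected step is a 1.1-fold higher number from compound 3 to compound 4 (0.04 log units; within the scatter) and nothing beyond the scatter is anticipated. Compound 4 is estimated at 1100 umol/kg in this assay (expected range 550 umol/kg to 2200 umol/kg).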

Compound 4, dose for half-maximal effect: 1000 umol/kg
For compound 4 the middle estimate is 1.1-fold (0.04 log units) above the measured one, within the range that was stated.
By their numbers in this assay, from the lowest: compounds 2, 3, 4 and 1 (each within the scatter of the next).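

In this assay, within the data shown here, a methyl on the oxygen of the hydroxyamino group gives no change at the digits printed from compound 3 to compound 4 (within the scatter) and so stays within the scatter, which shows for the first time that this oxygen can carry either hydrogen or methyl with the change in this read-out alone in view. The nitrogen of the methoxyamino group behaves the same way, since hydrogen in place of methyl there gives no change at the digits printed from compound 2 to compound 4 (within the scatter) and methoxy in place of methyl on that nitrogen gives a 1.8-fold lower number from compound 1 to compound 4 (0.26 log units; within the scatter) as well, so none of the four compounds can be ranked against another in this assay and every substitution tried on this amide so far has left the number within the scatter. No evidence is available on what lies behind these small steps.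

On these data alone, what remains open is whether a longer chain on the oxygen, such as ethyl or benzyl, would move the number beyond the scatter at all. As far as these compounds go, it is equally open whether replacing the whole methoxyamino group with a carboxylic acid or a primary amide would do so, or whether the read-out depends on this part of the molecule at all.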